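The source may report more compounds than this note shows. Statements on the series, on what has been measured and on what is new or still open speak of the compounds shown alone.

Three compounds on one shared core differ in the aryl group they carry. In a physicochemical assay for permeability, using PAMPA (a lower number here means that the compound crosses the layer more slowly, a higher number that the compound crosses the layer faster), compound 1 `Cc1oc(-c2ccc(Cl)cc2)nc1CN1CCC(C(=O)NCCCN2C[C@H](C)C[C@H](C)C2)CC1` reads > 635 10^-6 cm/s, and this entry is a limit of the assay, not a number. Compound 2 `Cc1oc(-c2c(Cl)cccc2Br)nc1CN1CCC(C(=O)NCCCN2C[C@H](C)C[C@H](C)C2)CC1` has the entry "not determined" (no result reported) in this assay, so it gives no result. Compound 3 `Cc1oc(-c2c(Cl)cccc2C(F)(F)F)nc1CN1CCC(C(=O)NCCCN2C[C@H](C)C[C@H](C)C2)CC1` stands the same way, with the entry "not determined" (no result reported) and no number of its own.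

The next structure is compound 4 `COc1cccc(Br)c1-c1nc(CN2CCC(C(=O)NCCCN3C[C@H](C)C[C@H](C)C3)CC2)c(C)o1`. The change 2-bromo-6-methoxyphenyl in place of 2-chloro-6-(trifluoromethyl)phenyl on an aromatic carbon puts 2-bromo-6-methoxyphenyl in place of 2-chloro-6-(trifluoromethyl)phenyl on an aromatic carbon.

Compound 3 offers no number to measure a step from, and no step beyond the scatter is expected from this swap, in either direction. Going by the values given here, the only guide is compound 1 with its limit of > 635 10^-6 cm/s in this assay, so a high reading is expected, and a limit is possible. Compound 4 is estimated at 400 10^-6 cm/s, with an expected range from 100 10^-6 cm/s to 635 10^-6 cm/s in this assay for this measurement.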

Compound 4, apparent permeability: 245 10^-6 cm/s
Compound 4: middle estimate off by 1.6-fold (0.21 log units), on the high side, within the range that was stated.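

In this assay, going by these compounds alone, compound 4 gives the first reading on the shared core that is a number and not a limit, so the series now has a measured point at this position. Placing 2-bromo-6-methoxyphenyl in place of 4-chlorophenyl on this aromatic carbon gives an at least 2.5-fold lower number from compound 1 to compound 4 (0.41 log units; beyond the scatter), which shows that the reading responds to the aryl group carried here. The entry for compound 1 is a limit and not a number, so the true size of this step stays unknown: the limit of > 635 10^-6 cm/s in this assay, at which 1 of the 4 values shown sits.

Steps from compound 2 and compound 3 cannot be read, so it remains open whether the bromine, the methoxy group or the two together account for the step. On these data alone, how an aryl group bearing an amine or a carboxylic acid would read in this assay also remains open.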